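The source may report more compounds than this note shows. Statements on the series, on what has been measured and on what is new or still open speak of the compounds shown alone.

The measured compounds:

Compound 1, `CCOc1cc(NC(=O)NCc2cc(C)c(-c3cn(C)nc3C(F)(F)F)nn2)cc(C)n1`, gives 194000 nM in a functional assay on HFL1 cells for antagonist activity at sphingosine 1-phosphate receptor 2 (Homo sapiens), read by ELISA, with a stated time of 24 h, in the presence of a further agent that is not named here; a lower number here means a stronger inhibitor, a higher number a weaker inhibitor.

Compound 2, `CCOc1nc(C)cc(NC(=O)NCc2cc(C)c(-c3cn(C)nc3C(F)(F)F)nn2)c1Cl`, gives 49000 nM in this assay.

Within the data shown here, compound 2 holds the lower of the two numbers so far. Among the measured compounds shown here, the only measured step, a 4.0-fold lower number from compound 1 to compound 2 (0.60 log units; beyond the scatter), is modest but beyond the scatter and came from putting chloro in place of hydrogen on an aromatic carbon of the shared core.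

Compound 3, `CCOc1nc(C)cc(NC(=O)NCc2cc(C)c(-c3cn(C)nc3C(F)(F)F)nn2)c1C#N`, has not yet been measured. It differs from compound 2 by cyano in place of chloro on an aromatic carbon. For the measured compounds named here, the one measured step bears on this only loosely: it tells how the ring behaves when a hydrogen gives way to chloro at that carbon, not how chloro compares with cyano there. Going by the values given here, no measured pair shows a cyano group at all. On this slender basis no step beyond the scatter is expected, in either direction, and the estimate for compound 3 is therefore kept close to compound 2. Compound 3 is expected to give about 40000 nM in this assay, with a range from 12000 nM to 130000 nM. This expectation corresponds to a step of a 1.2-fold lower number from compound 2 to compound 3 (0.09 log units; within the scatter).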

Compound 3, half-maximal inhibitory concentration: > 30000000 nM
Compound 3 ended at the assay's limit; the forecaster's own chance of this, stated with the estimate: 20%; middle value at least 750-fold (2.87 log units) away from the limit.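

The carbon ortho to a large group and ortho to an ethoxy group turns out to be far more sensitive to what it carries than the chloro step alone showed: in this assay, cyano in place of chloro brings an at least 610-fold higher number from compound 2 to compound 3 (2.78 log units; beyond the scatter), and cyano in place of hydrogen brings an at least 150-fold higher number from compound 1 to compound 3 (2.18 log units; beyond the scatter). The same carbon therefore moves the number in opposite directions depending on the group, since chloro in place of hydrogen brought a 4.0-fold lower number from compound 1 to compound 2 (0.60 log units; beyond the scatter), while cyano leaves compound 3 behind both of the other compounds. Compound 3 stands at a limit and not at a number: the limit of > 30000000 nM in this assay, at which 1 of the 3 values shown sits.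

The compounds shown leave open what sets chloro and cyano so far apart at this carbon, as nothing here measures a difference between the two groups other than the read-out itself. They also leave open whether bromo, an amine or a carboxylic acid on this carbon would follow chloro or cyano, and whether a longer chain in place of the ethoxy group would alter the effect of either.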